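Replacing 2-methylphenyl with furan-2-yl on a shared core

The source may report more compounds than this note shows. Statements on the series, on what has been measured and on what is new or still open speak of the compounds shown alone.

Three compounds share one core and differ only in the group on a double-bonded chain carbon bound to a double-bonded chain carbon. In a functional assay on HCT-8 cells (Homo sapiens) for cytotoxicity (on this read-out lower numbers stand for an effect already at smaller amounts and higher numbers for an effect only at larger amounts of compound), compound 1 `COC1=C(C)C(=O)/C(=C(O)/C=C/c2ccc(O)cc2)C(=O)C1(C)C` gives 14.8 ug/mL and compound 2 `COC1=C(C)C(=O)/C(=C(O)/C=C/c2ccccc2C)C(=O)C1(C)C` gives 4 ug/mL, so compound 2 holds the lower of the two numbers. In compound 3 `COC1=C(C)C(=O)/C(=C(O)/C=C/c2ccco2)C(=O)C1(C)C`, furan-2-yl stands in place of 2-methylphenyl at that same place: furan-2-yl in place of 2-methylphenyl on a double-bonded chain carbon bound to a double-bonded chain carbon. Among the measured compounds shown here, only one measured step bears on this change: a 3.7-fold lower number from compound 1 to compound 2 (0.57 log units; beyond the scatter). That modest step shows that the group at this place can move the number in this assay. However, it involved a different exchange, and no furan-2-yl compound has been measured yet, so it suggests a size more firmly than a direction. For the measured compounds named here, with compound 2 at 4 ug/mL, the lower of only two numbers, a modest move toward a higher number seems the likelier outcome. The expected step is a 2.3-fold higher number from compound 2 to compound 3 (0.35 log units; beyond the scatter). For compound 3 the estimated value is 9 ug/mL, with an expected range from 3 ug/mL to 25 ug/mL.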

Compound 3, concentration for half-maximal effect: 17.5 ug/mL
For compound 3 the middle estimate is 1.9-fold (0.29 log units) below the measured one; measured number inside the range.
By their numbers in this assay, from the lowest: compound 2; then compounds 1 and 3 (each within the scatter of the next).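

In this assay the exchange of 2-methylphenyl for furan-2-yl gives a 4.4-fold higher number from compound 2 to compound 3 (0.64 log units; beyond the scatter) and so undoes the low number of compound 2, which now stands apart as the lowest of the three. The exchange of 4-hydroxyphenyl for furan-2-yl gives a 1.2-fold higher number from compound 1 to compound 3 (0.07 log units; within the scatter), so this read-out does not separate these two groups, even though one is a six-membered carbon ring and the other a five-membered ring with a hetero atom, and only 2-methylphenyl has so far brought the number clearly down at this place on the double-bonded chain carbon. Nothing available on these compounds accounts for the gap between 2-methylphenyl and the other two groups.

Three groups cannot show whether the lower number of compound 2 belongs to its methyl group or to the whole ring, and a plain phenyl group on the same core would be the direct comparison for that question. Also open, going by these compounds, is how groups of a different kind, such as an amine-bearing phenyl ring or a longer alkyl chain, would behave at this place.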